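Lengthening the acid chain on a bis-aryl ether

The source may report more compounds than this note shows. Statements on the series, on what has been measured and on what is new or still open speak of the compounds shown alone.

Measured so far:
compound 1, `CCCc1c(OCCCOc2cccc(OCC(=O)O)c2)ccc(C(C)=O)c1O`, 500 nM
compound 2, `CCCc1c(OCCCOc2c(C(C)=O)ccc(OCCCC(=O)O)c2CCC)ccc(C(C)=O)c1O`, 200 nM
compound 3, `CCCc1c(OCCCCCOc2c(C(C)=O)ccc(OCC(=O)O)c2CCC)ccc(C(C)=O)c1O`, 100 nM

All three were tested in a functional assay on ileum (Cavia porcellus) for inhibition of cysteinyl leukotriene receptor (Homo sapiens); a higher number here means a weaker inhibitor, a lower number a stronger inhibitor. Compound 3 has the lowest number of the three. Against compound 2 the gap is within the usual scatter, so the two cannot be told apart; against compound 1 the gap is beyond the scatter, so compound 3 is the stronger inhibitor of that pair.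

Compound 4, `CCCc1c(OCCCCCOc2c(C(C)=O)ccc(OCCCC(=O)O)c2CCC)ccc(C(C)=O)c1O`, has not been measured. It differs from compound 3 in one place: 2-carboxyethyl in place of carboxy on a saturated chain carbon bound to an oxygen on an aromatic ring. Going by the values given here, the same change, with a shorter link between the two aromatic parts, is seen between compound 1 and compound 2, but those two also differ elsewhere, so no clean step is available.

The step from compound 3 to compound 4 is expected to be small, toward a lower number or none beyond the scatter: a 1.4-fold lower number from compound 3 to compound 4 (0.15 log units; within the scatter). Compound 4 is expected to give 70 nM, in the range 20 nM to 250 nM.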

Compound 4, half-maximal inhibitory concentration: 1000 nM
The estimate for compound 4 lay 14-fold (1.15 log units) below the measured number; the measured number lies above the stated range.
By their numbers in this assay, from the lowest: compounds 3 and 2 (each within the scatter of the next); then compounds 1 and 4 (each within the scatter of the next).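

Going by these compounds alone, this is the first clean reading of the acid chain at this position. In this assay, the change from carboxymethoxy to 3-carboxypropoxy on the shared core gives a 10-fold higher number from compound 3 to compound 4 (1.00 log units; beyond the scatter), so in this pair, lengthening the chain that carries the acid weakens inhibition rather than leaving it unchanged. No measurement on hand accounts for this loss.

As far as these compounds go, compound 1 and compound 2 also differ elsewhere, so whether the same change has the same effect with a shorter link between the two aromatic parts remains open. Also open, from the compounds shown here alone, is how a 2-carboxyethoxy chain, of intermediate length, or a tetrazole in place of the carboxylic acid would read in this assay.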